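The source may report more compounds than this note shows. Statements on the series, on what has been measured and on what is new or still open speak of the compounds shown alone.

Working notes on the series, measured in a functional assay on HeLa cells (Homo sapiens) for cytotoxicity, read by MTT assay, with a stated time of 48 h; a higher number here means a weaker inhibitor, a lower number a stronger inhibitor:

- compound 1 `O=C(/C=C/c1cccc(F)c1)Nc1ccc(CC2=CC(=O)OC2)cc1`: 49000 nM
- compound 2 `O=C(/C=C/c1ccccc1F)Nc1ccc(CC2=CC(=O)OC2)cc1`: 45800 nM
- compound 3 `C=C1OC(=O)C=C1Cc1ccc(NC(=O)/C=C/c2ccccc2)cc1`: 7340 nM

Compound 1 stands at the high end of these numbers. Among the measured compounds shown here, the one measured step, 2-fluorophenyl in place of 3-fluorophenyl, is a 1.1-fold lower number from compound 1 to compound 2 (0.03 log units; within the scatter).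

The unmeasured compound 4 `C=C1OC(=O)C=C1Cc1ccc(NC(=O)/C=C/c2cccc(F)c2)cc1` differs from compound 1 by a group of 7 heavy atoms (5 carbon, 2 oxygen; one five-membered non-aromatic ring with 1 hetero atom) in place of a group of 6 heavy atoms (4 carbon, 2 oxygen; one five-membered non-aromatic ring with 1 hetero atom), on a saturated chain carbon bound to an aromatic carbon. For the measured compounds named here, no measured step isolates this change, and the fluorine step above does not address it. Compound 3 already carries the entering group but lacks the fluorine, and it gives 7340 nM, a lower number than compound 1 at 49000 nM. The data include no fluorine-free partner bearing the leaving group. From the compounds shown here alone, how that gap divides between the two changes remains open. In this assay, a drop beyond the scatter is still expected, with compound 3 at 7340 nM as the closest guide. The expected step is a 6.1-fold lower number from compound 1 to compound 4 (0.79 log units; beyond the scatter). For compound 4 the estimated value is 8000 nM, with an expected range of 3500 nM to 18000 nM.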

Compound 4, half-maximal inhibitory concentration: 30200 nM
The estimate for compound 4 lay 3.8-fold (0.58 log units) below the measured number; measured number outside the range, above it.
By their numbers in this assay, from the lowest: compound 3; then compounds 4, 2 and 1 (each within the scatter of the next).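

In this assay, with the 3-fluorophenyl kept, the group of 7 heavy atoms in place of the group of 6 heavy atoms on a saturated chain carbon bound to an aromatic carbon does not separate the two compounds (a 1.6-fold lower number from compound 1 to compound 4 (0.21 log units; within the scatter)). Among the compounds shown here, with the group of 7 heavy atoms held constant, fluoro in place of hydrogen on an aromatic carbon is the step that lies beyond the scatter (a 4.1-fold higher number from compound 3 to compound 4 (0.61 log units; beyond the scatter)), so the first clean reading at this position shows little from the ring change alone. No measurement bears on the reason for either step.

Still open, from the compounds shown here alone, is whether the fluoro step seen with the group of 7 heavy atoms also appears with the group of 6 heavy atoms. Also open, going by these compounds, is whether an amine or a carboxylic acid in place of fluoro on that aromatic carbon would move the number in the same direction.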